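The compounds below may be only part of what the source reports. "The series", "measured", "known", "first", "only" and "open" are said of these compounds alone.

Measured compounds:
compound 1, `CC(C)C[C@@H](N)CN(C(=O)[C@@H]1C[C@H]1c1ccccc1)c1ccc(-c2ccccc2)cc1`, 1.8 nM
compound 2, `CC[C@H](C)[C@H](N)CN(C(=O)[C@@H]1C[C@H]1C1CCCCC1)c1ccc(-c2ccccc2)cc1`, > 25000 nM

The study measures agonism in a functional assay for agonist activity at G protein-coupled receptor 88 (Homo sapiens), read by HTRF and cAMP accumulation; on this read-out higher numbers stand for an effect only at larger amounts of compound and lower numbers for an effect already at smaller amounts. Compound 1, `CC(C)C[C@@H](N)CN(C(=O)[C@@H]1C[C@H]1c1ccccc1)c1ccc(-c2ccccc2)cc1`, gives 1.8 nM in this assay. Compound 2, `CC[C@H](C)[C@H](N)CN(C(=O)[C@@H]1C[C@H]1C1CCCCC1)c1ccc(-c2ccccc2)cc1`, reaches only a limit of the assay, > 25000 nM, so no number is known for it, only that it lies beyond (the limit of > 25000 nM in this assay, at which 1 of the 2 values shown sits). For the measured compounds named here, compound 2 therefore stands at the weak end of the two values shown, with no measured step between it and compound 1 to rely on.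

Compound 3, `CC[C@H](C)[C@H](N)CN(C(=O)[C@@H]1C[C@H]1c1csc(C)n1)c1ccc(-c2ccccc2)cc1`, is the unmeasured compound. It differs from compound 2 in one place: 2-methyl-1,3-thiazol-4-yl in place of cyclohexyl on a saturated ring carbon. The rest of compound 2, including the shared core and the side chain bearing the amine, is kept.

Going by the values given here, no step between measured compounds is available, so the expectation rests on the two values alone. Compound 1 carries an aromatic ring on the three-membered ring and gives 1.8 nM. Compound 2, with cyclohexyl in that place, sits at a limit of the assay. The step of an at least 410-fold lower number from compound 2 to compound 3 (2.61 log units; beyond the scatter) is therefore expected to be large toward lower numbers, well beyond the scatter. Compound 3 is estimated at 60 nM, within 5 nM to 1500 nM.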

Compound 3, half-maximal effective concentration: 1500 nM
For compound 3 the middle estimate is 25-fold (1.40 log units) below the measured one, within the range that was stated.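

For the compounds shown here, the change of cyclohexyl to 2-methyl-1,3-thiazol-4-yl on a saturated ring carbon of the three-membered ring gives the first comparison in one place, read in this assay: an at least 16-fold lower number from compound 2 to compound 3 (1.22 log units; beyond the scatter). With the shared core and the side chain bearing the amine kept, this one group is enough to bring a compound from the limit into the measured range, even though the group that leaves and the group that enters have the same count of heavy atoms. The value of compound 2, > 25000 nM, is a limit and not a number, so the step gives only a lower bound on its size: the limit of > 25000 nM in this assay, at which 1 of the 3 values shown sits.

The compounds shown leave open whether the aromatic ring, its hetero atoms or its methyl accounts for the step, a question that a 1,3-thiazol-4-yl without the methyl or a pyridin-2-yl at this place would help to separate. They also leave open whether the same exchange would carry over to the side chain of compound 1, since no pair shown tests this position on that side chain.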